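This account rests on a few compounds, and the source may have more. Where it says the series, first, only, none or still open, it means among the compounds named here.

Of the compounds shown here, three have been measured in a functional assay on MCF7 cells (Homo sapiens) for inhibition, read by MTT assay, with a stated time of 72 h; on this read-out higher numbers stand for weaker inhibition of growth and lower numbers for stronger inhibition of growth. Compound 1, `CC(C)=CC(=O)NC(=N)N`, is the smallest of them: in this assay compound 1 reaches only the limit of the assay, > 100000 nM, which is a limit and not a number. Compound 3, `CC(C)=CCC/C(C)=C/C(=O)NC(=N)N`, carries a longer chain on the same guanidine core, and in this assay compound 3 gives 52200 nM. Compound 2, `CC(C)=CCC/C(C)=C/CC/C(C)=C/C(=O)NC(=N)NC(=O)/C=C(\C)CC/C=C(\C)CCC=C(C)C`, is built differently, with a long chain on each side of the guanidine; in this assay compound 2 gives 30300 nM. The difference between the core of compound 2 and the core of compound 3 is not broken down here.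

Among the compounds with values here, the one change that can be followed in the measurements is hydrogen in place of 3-methylbut-2-en-1-yl on a saturated chain carbon bound to a double-bonded chain carbon. Made on the core of compound 3, that change gave an at least 1.9-fold higher number from compound 3 to compound 1 (0.28 log units; that floor lies within the scatter), where the floor follows from the limit of > 100000 nM in this assay, at which 1 of the 3 values shown sits.

Compound 4, `CC(C)=CCC/C(C)=C/CC/C(C)=C/C(=O)NC(=N)NC(=O)/C=C(\C)CCC=C(C)C`, has not yet been measured. It arises from compound 2 by the same change, (hydrogen in place of 3-methylbut-2-en-1-yl on a saturated chain carbon bound to a double-bonded chain carbon), at the same kind of place. Since the shortening from compound 3 to compound 1 moved the number only modestly, an at least 1.9-fold higher number from compound 3 to compound 1 (0.28 log units; that floor lies within the scatter), a step of similar or smaller size is expected here, because compound 2 starts from 30300 nM and keeps one long chain. The expected step is a 1.5-fold higher number from compound 2 to compound 4 (0.17 log units; within the scatter). Compound 4 is therefore estimated at 45000 nM, most likely between 20000 nM and 100000 nM.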

Compound 4, concentration for 50% growth inhibition: 51200 nM
For compound 4 the middle estimate is 1.1-fold (0.06 log units) below the measured one; the range from low to high includes it.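

In this assay, replacing the 3-methylbut-2-en-1-yl group with hydrogen, at a saturated chain carbon bound to a double-bonded chain carbon, gives a 1.7-fold higher number from compound 2 to compound 4 (0.23 log units; within the scatter), so shortening this chain produces no change that can be told apart from ordinary assay variation. The same chain shortening can now be set side by side on two different cores, and the comparison reads: the same change on two cores in this assay, an at least 1.9-fold higher number (0.28 log units; that floor lies within the scatter) from compound 3 to compound 1 and a 1.7-fold higher number (0.23 log units; within the scatter) from compound 2 to compound 4; the limit leaves it open whether they differ. This shows nothing that speaks against the change carrying over from one core to the other, but it does not show that the step has the same size on both, since the earlier step is only a floor and compound 1 gives a limit rather than a number: the limit of > 100000 nM in this assay, at which 1 of the 4 values shown sits.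

Two cores are also a very small sample, and neither step is printed as lying beyond the scatter, so no firm rule for the series can be drawn from them. The compounds shown leave open whether a longer chain than any here, or a chain ending in an amine or a carboxylic acid in place of the 3-methylbut-2-en-1-yl group, would move the number by a clear margin.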